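This account rests on a few compounds, and the source may have more. Where it says the series, first, only, none or still open, it means among the compounds named here.

The measured compounds and their values in a functional assay on PANC-1 cells (Homo sapiens) for inhibition, read by MTT assay, with a stated time of 24 h, tested at 10 uM; a higher number here means more inhibition at the concentration tested (going by the name of the read-out), a lower number less inhibition:
compound 1 `CC(C)=CCC/C(C)=C/CC1Cc2c(OCCCNS(=O)(=O)c3ccc(Br)cc3)cc(=O)n(CCCO)c2CC1(C)C` gives 15.2%
compound 2 `CC(C)=CCC/C(C)=C/CC1Cc2c(OCCCNC(=O)c3cccs3)cc(=O)n(CCCO)c2CC1(C)C` gives 72.8%
compound 3 `COc1ccc(OCCCOc2cc(=O)n(CCCO)c3c2CC(C/C=C(\C)CCC=C(C)C)C(C)(C)C3)cc1` gives 20%

Compound 3 stands second highest of these three numbers. Its nearest neighbour is compound 1, and the step of a number 4.8 percentage points higher from compound 1 to compound 3 (within the scatter) lies within the scatter, so the two cannot be ordered. The step of a number 52.8 percentage points lower from compound 2 to compound 3 (beyond the scatter), by contrast, is large and well beyond the scatter.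

Compound 4 `CC(C)=CCC/C(C)=C/CC1Cc2c(OCCCOc3ccc(Cl)cc3)cc(=O)n(CCCO)c2CC1(C)C` differs from compound 3 in one place on the tail: chloro in place of methoxy on an aromatic carbon. Going by the values given here, no measured step alters this substituent alone. The two steps that end in compound 3 each replace the whole group on the chain, together with the atom joining it to the chain, so they bear only loosely on a swap of methoxy for chloro. Among the compounds with values here, the one other compound carrying a halogen on its aromatic ring, compound 1, sits in the same low region as compound 3.

Compound 4 is therefore expected to show a step of a number 2 percentage points higher from compound 3 to compound 4 (within the scatter) that does not pass beyond the scatter. Compound 4 is estimated to give 22% in this assay, within a range from 5% to 45%.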

Compound 4, a percentage reported as inhibition, at one concentration (the size of the read-out at that concentration, not a potency): 25.2%
Beside the measured number, compound 4's estimate is 3.2 percentage points below it, and the stated range covers the measured number.
By their numbers in this assay, from the lowest: compounds 1, 3 and 4 (each within the scatter of the next); then compound 2.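

Going by these compounds alone, the step of a number 5.2 percentage points higher from compound 3 to compound 4 (within the scatter) is the first direct reading of a swap on this aromatic carbon, para to a large group, and in this assay it leaves methoxy and chloro impossible to tell apart at this one concentration. With the chloro group in place, the 4-chlorophenoxy compound still falls well short of the thiophene amide, as the step of a number 47.6 percentage points lower from compound 2 to compound 4 (beyond the scatter) shows, while the step of a number 10 percentage points higher from compound 1 to compound 4 (within the scatter) leaves it unresolved from the sulfonamide, so among these compounds compound 2 alone stands apart and neither ether's substituent brings the reading near it. Nothing available here accounts for either the similarity of the two ethers or the distance from compound 2.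

The compounds shown leave open whether this aromatic carbon responds to any group at all, since only methoxy and chloro are compared there, and an amine or a carboxylic acid at that place could read differently. They also leave open whether the high reading of compound 2 belongs to the thiophene ring or to the amide link, which a furan-2-carbonyl or benzoyl amide on the same chain would separate.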